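This account rests on a few compounds, and the source may have more. Where it says the series, first, only, none or still open, it means among the compounds named here.

Going by the values given here, compound 3, with the structure `COc1ccccc1-n1nc(C2CC(C)(C)OC(C)(C)C2)cc1-c1ccc(Cl)cc1`, is the strongest inhibitor among the three compounds measured so far: in an assay on HEK293 cells for inhibition of Voltage-dependent N-type calcium channel subunit alpha-1B (Homo sapiens), read by patch clamp, using a membrane potential dye (a higher number here means a weaker inhibitor, a lower number a stronger inhibitor), compound 3 gives 24 nM. Its two neighbours differ from it in one place each. Compound 2, `COc1ccccc1-n1nc([C@H]2C[C@@H](C)O[C@@H](C)C2)cc1-c1ccc(Cl)cc1`, carries a smaller oxane group and gives 91 nM in this assay; the step of a 3.8-fold lower number from compound 2 to compound 3 (0.58 log units; beyond the scatter) is modest. Compound 1, `COc1ccccc1-n1nc(C2CC(C)(C)OC(C)(C)C2)cc1-c1ccnc(Cl)c1`, carries a chloropyridine ring instead of the chlorophenyl ring and gives 740 nM; the step of a 31-fold lower number from compound 1 to compound 3 (1.49 log units; beyond the scatter) is large.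

Compound 4, `COc1ccccc1-n1nc(C2CC(C)(C)OC(C)(C)C2)cc1-c1ccc(C#N)cc1`, keeps the core and the oxane of compound 3 and alters only the aromatic ring: cyano in place of chloro on an aromatic carbon. Neither measured step touches this exact spot, so none bears on it directly. Among the compounds with values here, the large step from compound 1 to compound 3 shows only that this ring is sensitive to change, not how a cyano group will behave. An expectation can therefore be only a cautious one: a modest step of a 2.5-fold higher number from compound 3 to compound 4 (0.40 log units; beyond the scatter) toward a weaker inhibitor is expected, with the real possibility of none beyond the scatter. Compound 4 is estimated at 60 nM, within a range of 15 nM to 250 nM.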

Compound 4, half-maximal inhibitory concentration: 130 nM
Beside the measured number, compound 4's estimate is 2.2-fold (0.34 log units) below it, and the stated range covers the measured number.
By their numbers in this assay, from the lowest: compound 3; then compounds 2 and 4 (each within the scatter of the next); then compound 1.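

Compound 4 is the first compound shown to keep the six-membered aromatic ring of carbon only and change just the group on the aromatic carbon para to a large group. In this assay, a 5.4-fold higher number from compound 3 to compound 4 (0.73 log units; beyond the scatter) shows that at this position a cyano group gives a weaker inhibitor than chloro, so the sensitivity of this part of the molecule extends beyond swapping the ring itself. The 4-cyanophenyl compound still improves on the 2-chloropyridin-4-yl compound, with a 5.7-fold lower number from compound 1 to compound 4 (0.76 log units; beyond the scatter), although the data shown offer no explanation for either step.

The compounds shown leave open how a methyl, methoxy or trifluoromethyl group at this position would compare with chloro and cyano. They also leave open whether the step from chloro to cyano would be of similar size alongside the 2,6-dimethyloxan-4-yl group of compound 2, as cyano appears here only with the 2,2,6,6-tetramethyloxan-4-yl group.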